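Sulfur substituent variation on the shared core

The compounds below may be only part of what the source reports. "The series", "measured", "known", "first", "only" and "open" are said of these compounds alone.

Compound 1 `C#CCSc1nc(Nc2cccc(OC)c2)c2ccncc2n1` and compound 2 `C/C=C/Sc1nc(Nc2cccc(OC)c2)c2ccncc2n1` differ only on a sulfur. In a functional assay on MGC-803 cells (Homo sapiens) for inhibition, read by MTT assay, with a stated time of 72 h (a higher number here means a weaker inhibitor, a lower number a stronger inhibitor), compound 1 gives 2070 nM and compound 2 gives 1030 nM. Compound 2 thus holds the smaller of the two numbers, but the step of a 2.0-fold lower number from compound 1 to compound 2 (0.30 log units; within the scatter) is within the scatter. Compound 3 `COc1cccc(Nc2nc(SCC3CC3)nc3cnccc23)c1` carries cyclopropylmethyl in place of prop-1-en-1-yl on a sulfur. Going by the values given here, the only measured step bearing on this change is a 2.0-fold lower number from compound 1 to compound 2 (0.30 log units; within the scatter), which stayed within the scatter, so no step beyond the scatter is expected here; the expected step is a 1.2-fold higher number from compound 2 to compound 3 (0.07 log units; within the scatter). Compound 3 is estimated at 1200 nM in this assay, with a range from 400 nM to 4000 nM.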

Compound 3, half-maximal inhibitory concentration: 1340 nM
Beside the measured number, compound 3's estimate is 1.1-fold (0.05 log units) below it, and the stated range covers the measured number.
By their numbers in this assay, from the lowest: compounds 2, 3 and 1 (each within the scatter of the next).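

In this assay, moving to cyclopropylmethyl, a saturated group with a three-membered ring, gives a 1.3-fold higher number from compound 2 to compound 3 (0.11 log units; within the scatter) and a 1.5-fold lower number from compound 1 to compound 3 (0.19 log units; within the scatter). Neither the loss of the double bond of prop-1-en-1-yl nor the entry of a ring and one more carbon produces a step beyond the scatter, so propargyl, prop-1-en-1-yl and cyclopropylmethyl on this sulfur cannot be told apart here. No evidence on hand speaks to what lies behind this flat result. Going by these compounds, whether an amine, a carboxylic acid or a longer alkyl chain on the sulfur would give a step beyond the scatter remains open.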